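Chloro to fluoro exchange on two related cores

The source may report more compounds than this note shows. Statements on the series, on what has been measured and on what is new or still open speak of the compounds shown alone.

Measured so far in a functional assay on T47D cells (Homo sapiens) for inhibition, read by sulforhodamine B assay, with a stated time of 48 h; a lower number here means a stronger inhibitor of growth, a higher number a weaker inhibitor of growth:
compound 1, `COC(=O)[C@@]1(C)CCC=C2[C@@H]1CC[C@@H](C)[C@]2(C)Cc1c(C)[nH]c2ccc(Cl)cc12`, gives 17000 nM
compound 2, `COC(=O)[C@@]1(C)CCC=C2[C@@H]1CC[C@@H](C)[C@]2(C)Cc1c(C)[nH]c2ccc(F)cc12`, gives 15000 nM
compound 3, `COC(=O)[C@@]1(C)CC[C@@H]2C3=C1CC[C@@H](C)[C@]3(C)C[C@@H]1c3cc(Cl)ccc3N[C@H]21`, gives 28000 nM

Compound 1 and compound 2 share one core and differ only in the halogen: fluoro in place of chloro on an aromatic carbon. The step in this assay is a 1.1-fold lower number from compound 1 to compound 2 (0.05 log units; within the scatter), so the two values are indistinguishable within the usual scatter of this measurement.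

Compound 3 carries a different core; the difference between the two cores is not broken down here. Its value in this assay stands closest to that of compound 1 and furthest from that of compound 2, but both gaps remain within the scatter, so no order among the three compounds can be stated.

Compound 4, `COC(=O)[C@@]1(C)CC[C@@H]2C3=C1CC[C@@H](C)[C@]3(C)C[C@@H]1c3cc(F)ccc3N[C@H]21`, is not yet measured. It relates to compound 3 as compound 2 relates to compound 1: fluoro in place of chloro on an aromatic carbon. The two place descriptions are not identical: in compound 1 the ring is part of a fused or bridged system of two rings, in compound 3 of five rings, so this is the same kind of change rather than the same change. Going by the values given here, the one measured example, compound 1 to compound 2, gave a 1.1-fold lower number from compound 1 to compound 2 (0.05 log units; within the scatter). Among the compounds with values here, on that basis the step from compound 3 to compound 4 in this assay is expected to be about a 1.1-fold lower number from compound 3 to compound 4 (0.03 log units; within the scatter), resting on the single step between compound 1 and compound 2 and on the value of compound 3, 28000 nM. Compound 4 is accordingly estimated at 26000 nM, with a range of 13000 nM to 52000 nM.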

Compound 4, concentration for 50% growth inhibition: 27000 nM
For compound 4 the middle estimate is 1.0-fold (0.02 log units) below the measured one; the range from low to high includes it.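

On the core of compound 3, in this assay, fluoro in place of chloro on an aromatic carbon gives a 1.0-fold lower number from compound 3 to compound 4 (0.02 log units; within the scatter), so on this core too the exchange produces no readable difference. Set beside the same exchange on the other core, the two steps do not differ: the same change on two cores in this assay, a 1.1-fold lower number (0.05 log units; within the scatter) from compound 1 to compound 2 and a 1.0-fold lower number (0.02 log units; within the scatter) from compound 3 to compound 4, 1.1-fold (0.04 log units) apart, within the scatter of two such steps This shows that, in this assay, the swap between these two halogens was equally silent on both cores, so a neutral result carried from one core to the other; it does not show that the same would hold on any further core or in any other assay, nor that the aromatic substituent is without influence on growth inhibition in general.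

All four compounds carry either chloro or fluoro on the aromatic ring, so the compounds shown leave open what a methoxy group, a nitrile or an amine on that aromatic carbon would do to the number in this assay. Going by these compounds, all four also keep the methyl ester, and whether a carboxylic acid or an amide in its place would give a number beyond the scatter of the present values remains open as well.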